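A Chlorophenyl Swap on an Inactive Compound

The source may report more compounds than this note shows. Statements on the series, on what has been measured and on what is new or still open speak of the compounds shown alone.

The measured compounds share a core and differ in the group on a double-bonded chain carbon bound to a double-bonded chain carbon. In a functional assay on DU-145 cells (Homo sapiens) for inhibition, read by trypan blue exclusion, with a stated time of 96 h (a higher number here means a weaker inhibitor of growth, a lower number a stronger inhibitor of growth), compound 1 `O=C(/C(=C\c1ccc(Br)cc1)Sc1ccc(Br)cc1)c1ccc(Br)cc1`, which carries 4-bromophenyl there, gives 1000 nM. Compound 2 `O=C(/C(=C\c1c[nH]c2ccccc12)Sc1ccc(Br)cc1)c1ccc(Br)cc1`, which carries 1H-indol-3-yl, gives 1000 nM, so the swap shows no change at the digits printed from compound 1 to compound 2 (within the scatter).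

Compound 3 `Nc1c(Br)cc(Br)cc1/C=C(/Sc1ccc(Br)cc1)C(=O)c1ccc(Br)cc1` carries 2-amino-3,5-dibromophenyl and reads > 100000 nM, which is a limit of the assay and not a number. The two steps into this group are both large: an at least 100-fold higher number from compound 1 to compound 3 (2.00 log units; beyond the scatter) and an at least 100-fold higher number from compound 2 to compound 3 (2.00 log units; beyond the scatter).

Compound 4 `O=C(/C(=C\c1ccc(Cl)cc1)Sc1ccc(Br)cc1)c1ccc(Br)cc1` has not yet been measured in this assay. It gives up the group of compound 3 for another: 4-chlorophenyl in place of 2-amino-3,5-dibromophenyl on a double-bonded chain carbon bound to a double-bonded chain carbon. The entering 4-chlorophenyl differs from the 4-bromophenyl of compound 1 only in having chlorine where that group has bromine. The large step seen in an at least 100-fold higher number from compound 1 to compound 3 (2.00 log units; beyond the scatter) is therefore expected to run largely in reverse, back towards the level of compound 1 at 1000 nM. The expected change is an at least 100-fold lower number from compound 3 to compound 4 (2.00 log units; beyond the scatter), a large move to a lower number, which would mean a stronger inhibitor of growth. For compound 4 the estimate is 1000 nM, with an expected range from 300 nM to 4000 nM.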

Compound 4, concentration for 50% growth inhibition: 1000 nM
Compound 4: the middle estimate sits on the measured number at the digits printed; measured number inside the range.
By their numbers in this assay, from the lowest: compounds 1, 2 and 4 (each within the scatter of the next). At a limit, above all of these: compound 3.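

In this assay, the group on a double-bonded chain carbon bound to a double-bonded chain carbon can now be changed in two more ways without moving the reading: chloro in place of bromo on an aromatic carbon gives no change at the digits printed from compound 1 to compound 4 (within the scatter), and 4-chlorophenyl in place of 1H-indol-3-yl gives no change at the digits printed from compound 2 to compound 4 (within the scatter). Within the data shown here, replacing 2-amino-3,5-dibromophenyl with 4-chlorophenyl gives an at least 100-fold lower number from compound 3 to compound 4 (2.00 log units; beyond the scatter), so among the four compounds, 2-amino-3,5-dibromophenyl is the only group that stands apart. The size of that step is only a bound, because compound 3 sits at a limit of the assay and not at a number: the limit of > 100000 nM in this assay, at which 1 of the 4 values shown sits.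

The compounds shown leave open which part of 2-amino-3,5-dibromophenyl goes with the weak reading, as its amine and its bromines enter and leave together, and a plain 2-aminophenyl group would begin to separate them. Also open, from the compounds shown here alone, is how far the reading would hold with a group of a different kind at this place, such as a fluorophenyl, a carboxylic acid or a longer chain.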